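Cyano to ethoxycarbonyl on the side chain: cytotoxicity notes

A few compounds are considered here, and "the series" means these few. Any claim that something is new, unique, unknown or untested is made for them only; others in the source may bear on it.

Compound 1 `C=C[C@@](C)(/C=C/c1ccc(O)cc1)CC/C=C/C(=O)OCC` and compound 2 `C=C[C@@](C)(/C=C/c1ccc(O)cc1)CC/C=C/C#N` share a core; compound 3 `COc1ccc(/C=C/[C@@](C)(/C=C/c2ccc(O)c(/C=C/C#N)c2)CCC=C(C)C)cc1` has a different core, and how the two cores differ is not broken down here. In a functional assay on NALM-6 cells (Homo sapiens) for cytotoxicity, with a stated time of 72 h (on this read-out higher numbers stand for an effect only at larger amounts of compound and lower numbers for an effect already at smaller amounts), compound 1 gives only a limit, > 43400 nM. In this assay compound 2 also gives only a limit, > 43400 nM. Compound 3 gives a number in this assay, 16500 nM. The change from compound 2 to compound 1, (ethoxycarbonyl in place of cyano on a double-bonded chain carbon bound to a double-bonded chain carbon), shows a step that the two limits leave unreadable from compound 2 to compound 1, both values sitting at the limit of > 43400 nM in this assay, at which 2 of the 3 values shown sit. Compound 4 `CCOC(=O)/C=C/c1cc(/C=C/[C@](C)(/C=C/c2ccc(OC)cc2)CCC=C(C)C)ccc1O` carries the same change on the core of compound 3: ethoxycarbonyl in place of cyano on a double-bonded chain carbon bound to a double-bonded chain carbon. The measured pair leaves the size open, so compound 4 is expected to stay close to compound 3, with an estimated step of a 1.3-fold higher number from compound 3 to compound 4 (0.12 log units; within the scatter). Compound 4 is estimated at 22000 nM, between 8000 nM and 60000 nM.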

Compound 4, half-maximal effective concentration: > 43400 nM
Compound 4: no number, only a limit (the forecaster's own chance of this, stated with the estimate: 35%); middle value at least 1.9-fold (0.29 log units) away from the limit.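

On the core of compound 3, ethoxycarbonyl in place of cyano gives an at least 2.6-fold higher number from compound 3 to compound 4 (0.42 log units; beyond the scatter) in this assay, so on this core the change moves the read-out beyond the scatter. In this assay compound 4 gives only a limit, > 43400 nM, so the step has a lower bound and no full size. The step from compound 2 to compound 1 cannot be read, so the two cores cannot be compared and carry-over of the change between them is not shown: the limit of > 43400 nM in this assay, at which 3 of the 4 values shown sit.

From the compounds shown here alone, how a carboxylic acid or an amine in place of cyano on a double-bonded chain carbon would read stays open on both cores. Going by these compounds, whether any group on the core of compound 1 gives a number rather than a limit also stays open.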